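A few compounds are considered here, and "the series" means these few. Any claim that something is new, unique, unknown or untested is made for them only; others in the source may bear on it.

Measured so far in this study:

compound 1 `CCn1ncc(-c2nc3c(O[C@H]4CCN(C(=O)C5CCOCC5)C4)ncnc3n2C)c1C`: 0.8 h
compound 2 `CCn1ncc(-c2nc3c(O[C@H]4CCN(C(=O)C5CC5)C4)ncnc3n2C)c1C`: 0.4 h
compound 3 `CCn1ncc(-c2nc3c(N[C@H]4CCN(C(=O)C5CC5)C4)ncnc3n2C)c1C`: 0.3 h

In an ADME assay (Rattus norvegicus, strain Wistar Han) for metabolic stability (a lower number here means that the compound disappears faster, a higher number that the compound lasts longer), compound 1 gives 0.8 h. In the same test compound 2 gives 0.4 h, and compound 3 gives 0.3 h, the lowest of the three, although its gap to compound 2 is within the scatter. Compound 4 `CCn1ncc(-c2nc3c(N[C@H]4CCN(C(=O)C5CCOCC5)C4)ncnc3n2C)c1C` is not yet measured in this assay. It differs from compound 3 by oxan-4-yl in place of cyclopropyl on a carbonyl carbon. This is the same change as oxan-4-yl in place of cyclopropyl on a carbonyl carbon, which gave a 2.0-fold higher number from compound 2 to compound 1 (0.30 log units; within the scatter). How the core of compound 3 differs from the core of compound 2 is not broken down here. Because a 2.0-fold higher number from compound 2 to compound 1 (0.30 log units; within the scatter) was seen once, a step of a 2.0-fold higher number from compound 3 to compound 4 (0.30 log units; within the scatter) is expected for compound 4. Compound 4 is therefore estimated at 0.6 h, with an expected range of 0.3 h to 1.2 h.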

Compound 4, half-life: 0.2 h
Compound 4: middle estimate off by 3.0-fold (0.48 log units), on the high side, outside the stated range (below it).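

In this assay, oxan-4-yl in place of cyclopropyl on a carbonyl carbon gives a 1.5-fold lower number from compound 3 to compound 4 (0.18 log units; within the scatter), so the step seen on the core of compound 2 did not carry over to the core of compound 3. The two readings of this one change stand further apart than the scatter allows: the same change on two cores in this assay, a 2.0-fold higher number (0.30 log units; within the scatter) from compound 2 to compound 1 and a 1.5-fold lower number (0.18 log units; within the scatter) from compound 3 to compound 4, 3.0-fold (0.48 log units) apart, beyond the scatter of two such steps. Going by these compounds alone, each step alone lies within the scatter and each core offers a single pair, so this shows only that the step cannot be assumed to transfer between these two cores, not that the change has a set effect on either core, nor why the cores differ.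

Going by these compounds, it remains open whether a longer chain or a dimethylamino group in place of cyclopropyl on the carbonyl carbon would separate the two cores in the same way.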